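This account rests on a few compounds, and the source may have more. Where it says the series, first, only, none or still open, it means among the compounds named here.

Two measured compounds share the core. Compound 1 `Cc1ccccc1C(=O)Nc1cccc(/C=C/C(=O)c2nc3ccccc3[nH]2)c1` gives 8290 nM in a functional assay on 143B cells (Homo sapiens) for antiproliferative activity, read by MTT assay, with a stated time of 48 h; on this read-out lower numbers stand for stronger inhibition and higher numbers for weaker inhibition. Compound 2 `Cc1ccc(C(=O)Nc2cccc(/C=C/C(=O)c3nc4ccccc4[nH]3)c2)cc1` gives 6560 nM in this assay and holds the lower of the two numbers, with compound 1 nearest; the step of a 1.3-fold lower number from compound 1 to compound 2 (0.10 log units; within the scatter) concerns only where the methyl sits on the phenyl ring and stays within the scatter. Compound 3 `O=C(/C=C/c1cccc(NS(=O)(=O)c2cccc(Cl)c2)c1)c1nc2ccccc2[nH]1` carries a different change: (3-chlorophenyl)sulfonyl in place of (4-methylphenyl)carbonyl on a nitrogen on an aromatic ring. Among the compounds with values here, no measured step replaces the carbonyl link by a sulfonyl or exchanges a methyl for a chlorine, so nothing measured bears on it directly; the one step available, a 1.3-fold lower number from compound 1 to compound 2 (0.10 log units; within the scatter), is small and of another kind. With no guide to direction, no step beyond the scatter is assumed, and the range is kept wide. The expected step is a 1.1-fold lower number from compound 2 to compound 3 (0.04 log units; within the scatter). Compound 3 is estimated at 6000 nM, between 2000 nM and 18000 nM in this assay.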

Compound 3, half-maximal inhibitory concentration: 2510 nM
For compound 3 the middle estimate is 2.4-fold (0.38 log units) above the measured one, and the stated range covers the measured number.
By their numbers in this assay, from the lowest: compound 3; then compounds 2 and 1 (each within the scatter of the next).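

At the nitrogen on an aromatic ring, (3-chlorophenyl)sulfonyl in place of (4-methylphenyl)carbonyl gives a 2.6-fold lower number from compound 2 to compound 3 (0.42 log units; beyond the scatter) in this assay and, in place of (2-methylphenyl)carbonyl, gives a 3.3-fold lower number from compound 1 to compound 3 (0.52 log units; beyond the scatter) as the second step. Within the data shown here, these are the first steps to go beyond the scatter, so this position tolerates a change of both link and ring substituent and the read-out responds to it, whereas moving the methyl alone did not shift the number beyond the scatter. Nothing available bears on the reason for these steps.

The link and the ring substituent change together, so the compounds shown cannot divide the step between the sulfonyl and the chlorine; (4-methylphenyl)sulfonyl and (3-chlorophenyl)carbonyl would separate them. Also open, from the compounds shown here alone, is how a carboxylic acid or an amine on that phenyl ring would read.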